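The compounds below may be only part of what the source reports. "The series", "measured", "known", "first", "only" and "open" are said of these compounds alone.

Working notes on the series. The three measured analogues share one core; compound 1 `COc1cc2ncnc(Nc3ccc(F)c(Cl)c3)c2cc1OCCCCC(=O)Nc1ccc(S(N)(=O)=O)cc1` gives 35600 nM in a functional assay on NCI-H1975 cells (Homo sapiens) for antiproliferative activity, read by MTT assay, with a stated time of 72 h (a lower number here means a stronger inhibitor, a higher number a weaker inhibitor), compound 2 `C#Cc1cccc(Nc2ncnc3cc(OC)c(OCCCCC(=O)Nc4ccc(S(N)(=O)=O)cc4)cc23)c1` gives 18800 nM, and compound 3 `COc1cc2ncnc(Nc3cccc(Cl)c3)c2cc1OCCCCC(=O)Nc1ccc(S(N)(=O)=O)cc1` gives 33200 nM. Compound 3 sits second highest of the three numbers, nearest compound 1 and furthest from compound 2, with every gap within the scatter: a 1.1-fold lower number from compound 1 to compound 3 (0.03 log units; within the scatter), a 1.9-fold lower number from compound 1 to compound 2 (0.28 log units; within the scatter), a 1.8-fold higher number from compound 2 to compound 3 (0.25 log units; within the scatter).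

Compound 4 `COc1cc2ncnc(Nc3ccc(F)c(Br)c3)c2cc1OCCCCC(=O)Nc1ccc(S(N)(=O)=O)cc1` is not yet measured. The change is 3-bromo-4-fluorophenyl in place of 3-chlorophenyl on a nitrogen on an aromatic ring. For the measured compounds named here, the step that bears on it most directly is the fluoro-to-hydrogen swap, a 1.1-fold lower number from compound 1 to compound 3 (0.03 log units; within the scatter), which stayed within the scatter; no step that varies bromo against chloro has been run. No movement beyond the scatter is therefore expected in this assay, and compound 4 is estimated at 34000 nM, with a range of 15000 nM to 75000 nM, which means an expected step of a 1.0-fold higher number from compound 3 to compound 4 (0.01 log units; within the scatter).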

Compound 4, half-maximal inhibitory concentration: 31600 nM
Compound 4: the middle estimate sits 1.1-fold (0.03 log units) above what was measured; measured number inside the range.
By their numbers in this assay, from the lowest: compounds 2, 4, 3 and 1 (each within the scatter of the next).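

In this assay bromo in place of chloro gives a 1.1-fold lower number from compound 1 to compound 4 (0.05 log units; within the scatter) as the first direct read of that swap. 3-Bromo-4-fluorophenyl in place of 3-chlorophenyl gives a 1.1-fold lower number from compound 3 to compound 4 (0.02 log units; within the scatter) and in place of 3-ethynylphenyl gives a 1.7-fold higher number from compound 2 to compound 4 (0.23 log units; within the scatter) and so the four groups on this nitrogen remain unseparated. From the compounds shown here alone, whether an amine or a carboxylic acid on this phenyl group would move the number beyond the scatter stays open. No available evidence bears on this result.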